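This account rests on a few compounds, and the source may have more. Where it says the series, first, only, none or still open, it means among the compounds named here.

In a functional assay on CHO cells for positive allosteric modulation of metabotropic glutamate receptor 2 (Homo sapiens), read by scintillation counting and GTPgammaS binding, with a stated time of 30 min (a higher number here means that more compound is needed for the effect, a lower number that less compound is needed), compound 1 `COc1ccc(-c2ccn(CCC(C)C)c(=O)c2C#N)cc1Cl` gives 363 nM and compound 2 `CC(C)CCn1ccc(-c2ccc(OC3CCOCC3)c(Cl)c2)c(C#N)c1=O` gives 186 nM; compound 2 thus holds the lower of the two numbers, though the step of a 2.0-fold lower number from compound 1 to compound 2 (0.29 log units; within the scatter) stays within the scatter. Compound 3 `CC(C)CCn1ccc(-c2ccc(NC3CCOCC3)c(Cl)c2)c(C#N)c1=O` differs from compound 2 by (oxan-4-yl)amino in place of (oxan-4-yl)oxy on an aromatic carbon. Among the measured compounds shown here, no measured step bears on this exchange: the single step measured so far concerns a different change on the same oxygen, and it was within the scatter. Compound 3 is therefore expected to give 220 nM, with a range from 70 nM to 700 nM. The expected step of a 1.2-fold higher number from compound 2 to compound 3 (0.07 log units; within the scatter) is estimated to be no size beyond the scatter.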

Compound 3, half-maximal effective concentration: 174 nM
For compound 3 the middle estimate is 1.3-fold (0.10 log units) above the measured one; low and high end bracket the measured number.
By their numbers in this assay, from the lowest: compounds 3, 2 and 1 (each within the scatter of the next, the first and the last beyond it).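

In this assay the exchange of (oxan-4-yl)oxy for (oxan-4-yl)amino on this aromatic carbon gives a 1.1-fold lower number from compound 2 to compound 3 (0.03 log units; within the scatter) and so does not separate the two groups, although the amino group brings a hydrogen-bond donor. Against methoxy, the (oxan-4-yl)amino group gives a 2.1-fold lower number from compound 1 to compound 3 (0.32 log units; beyond the scatter) and is the only step here beyond the scatter, and only modestly so. Nothing available explains either step. The compounds shown leave open whether a plain amino group or a piperidin-4-ylamino group would hold this number at the same carbon. They also leave open what a fluoro group in place of the chloro group would do.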